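Chain-linked triazole chalcone amides: methoxy for fluoro

The source may hold more compounds than are shown below. What is called first, only, known or untested is meant among the compounds shown, and "the series" means these compounds.

Measured so far in a functional assay on MCF7 cells (Homo sapiens) for inhibition, read by MTT assay; on this read-out higher numbers stand for weaker inhibition and lower numbers for stronger inhibition:
compound 1, `CCCCCCCCCCn1cc(/C=C/C(=O)c2ccc(NC(=O)CN3CCN(c4ccccc4)CC3)cc2)nn1`, > 100000 nM
compound 2, `CCCCCCCCn1cc(/C=C/C(=O)c2ccc(NC(=O)CN3CCN(c4ccccc4OC)CC3)cc2)nn1`, 30000 nM
compound 3, `CCCCCCCCCCn1cc(/C=C/C(=O)c2ccc(NC(=O)CN3CCN(c4ccccc4F)CC3)cc2)nn1`, 40400 nM

Compound 1 gives only a limit of this assay, not a number. Compound 3 sits within the usual scatter of compound 2, so no order between the two can be read. Within the data shown here, the one step measured in this assay, an at least 2.4-fold lower number from compound 1 to compound 3 (0.39 log units; beyond the scatter), is bounded only by a limit, as the limit of > 100000 nM in this assay, at which 1 of the 3 values shown sits, sets it.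

Compound 4, `CCCCCCCCCCn1cc(/C=C/C(=O)c2ccc(NC(=O)CN3CCN(c4ccccc4OC)CC3)cc2)nn1`, is not yet measured. It differs from compound 3 by methoxy in place of fluoro on an aromatic carbon. Among the measured compounds shown here, no measured step covers this exchange directly; compound 2 carries the same methoxyphenyl group with a shorter chain, and its number and that of compound 3 lie within the scatter of each other. The expectation is therefore no step beyond the scatter, a 1.2-fold lower number from compound 3 to compound 4 (0.09 log units; within the scatter). Compound 4 is estimated at 33000 nM in this assay, expected between 12000 nM and 90000 nM.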

Compound 4, half-maximal inhibitory concentration: 44800 nM
The estimate for compound 4 lay 1.4-fold (0.13 log units) below the measured number; low and high end bracket the measured number.
By their numbers in this assay, from the lowest: compounds 2, 3 and 4 (each within the scatter of the next). At a limit, above all of these: compound 1.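

With the chain held constant, methoxy in place of fluoro at this position, ortho to a large group, gives a 1.1-fold higher number from compound 3 to compound 4 (0.04 log units; within the scatter) in this assay, and with the methoxyphenyl group held constant, the chain change gives a 1.5-fold higher number from compound 2 to compound 4 (0.17 log units; within the scatter), so neither exchange separates these compounds. Against the unsubstituted phenyl ring, methoxy gives an at least 2.2-fold lower number from compound 1 to compound 4 (0.34 log units; beyond the scatter), in the same direction as fluoro in compound 3. That step rests on a limit for compound 1, not on a number: the limit of > 100000 nM in this assay, at which 1 of the 4 values shown sits.

On these data alone, what remains open is whether an amine or a carboxylic acid at this position would move the number beyond the scatter of compounds 2, 3 and 4. As far as these compounds go, a longer chain on the triazole nitrogen is equally open, as is methoxy or fluoro elsewhere on the phenyl ring.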